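Cytotoxicity notes: chain terminus change on the shared core

The source may report more compounds than this note shows. Statements on the series, on what has been measured and on what is new or still open speak of the compounds shown alone.

Compound 1, `CCCCCCc1cc2cn([C@H]3C[C@H](O)[C@@H](CO)O3)c(=O)nc2o1`: in a functional assay on HEL cells (Homo sapiens) for cytotoxicity, read by microscopy (a higher number here means that more compound is tolerated, a lower number that less compound is tolerated), compound 1 gives > 50000 nM, a limit of the assay.
Compound 2, `C=CCCCCc1cc2cn([C@H]3C[C@H](O)[C@@H](CO)O3)c(=O)nc2o1`: in this assay compound 2 gives > 200000 nM, a limit.
Compound 3, `C=CCCCCCCCCc1cc2cn([C@H]3C[C@H](O)[C@@H](CO)O3)c(=O)nc2o1`: in this assay compound 3 gives > 50000 nM, a limit.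

All three values are limits, so compound 3 stands at the limit of > 50000 nM in this assay, at which 2 of the 3 values shown sit, together with compound 1, while compound 2 sits at the limit of > 200000 nM in this assay, at which 1 of the 3 values shown sits. Both steps into compound 3, a step that the two limits leave unreadable from compound 1 to compound 3 and a step that the two limits leave unreadable from compound 2 to compound 3, are unreadable, as is a step that the two limits leave unreadable from compound 1 to compound 2. Compound 4, `C#CCCCCc1cc2cn([C@H]3C[C@H](O)[C@@H](CO)O3)c(=O)nc2o1`, differs from compound 3 by ethynyl in place of hex-5-en-1-yl on a saturated chain carbon, four bonds along the chain from an aromatic carbon. The measured steps at this place give no readable size, so no step beyond the scatter is expected in this assay; the expected step is a number no higher from compound 3 to compound 4 (the limit leaves the size open). Compound 4 is estimated at 50000 nM, with a range from 20000 nM to 200000 nM, and most probably again only a limit will be reported.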

Compound 4, minimum cytotoxic concentration: > 200000 nM
Compound 4: a limit, no number (the forecaster's own chance of this, stated with the estimate: 90%); at least 4.0-fold (0.60 log units) between middle value and limit.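

Among these compounds, compound 4 is a limit, as are compound 1, compound 2 and compound 3, so no step between compound 4 and any of them can be read. The compounds shown leave open at what concentration any of them becomes cytotoxic in this assay.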